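Swapping 1,3-benzoxazol-2-yl for 1,3-benzothiazol-2-yl in compound 1

The compounds below may be only part of what the source reports. "The series", "measured", "known", "first", "only" and "open" are said of these compounds alone.

Values so far in a physicochemical assay for solubility, read by spectrophotometry, in phosphate buffer, measured as kinetic solubility, with a stated time of 18 h, at pH 7.4 (on this read-out lower numbers stand for lower solubility and higher numbers for higher solubility), as measured
- compound 1 `O=C(Nc1ccc(F)c(-c2nc3ccccc3o2)c1)c1cc([N+](=O)[O-])ccc1Cl` gives 270 nM
- compound 2 `COc1ccc(-c2nc3ccccc3o2)cc1NC(=O)c1cc([N+](=O)[O-])ccc1Cl` gives 90 nM

Of these two numbers compound 1 holds the higher. Compound 2 holds the lower, and this gap lies beyond the usual scatter of repeated measurements. The next compound to be read is compound 3 `O=C(Nc1ccc(F)c(-c2nc3ccccc3s2)c1)c1cc([N+](=O)[O-])ccc1Cl` and it departs from compound 1 in one place. There, 1,3-benzothiazol-2-yl stands in place of 1,3-benzoxazol-2-yl on an aromatic carbon 1,3-benzothiazol-2-yl in place of 1,3-benzoxazol-2-yl on an aromatic carbon and the group remains ortho to a fluoro group. Going by the values given here, no pair of measured compounds shows this exchange, so its size in this assay has not been observed directly. Among the compounds with values here, the only guide is the spread of the measured numbers, with compound 1 at 270 nM and compound 2 at 90 nM as its two ends. On that thin basis a small downward move is expected, and the range is kept wide. The expected step runs a 1.9-fold lower number from compound 1 to compound 3 (0.29 log units; within the scatter) and remains an estimate. For compound 3 the expected value is 140 nM and the estimated range runs from 45 nM to 420 nM on this read-out.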

Compound 3, solubility: 490 nM
Estimate against measurement, compound 3: 3.5-fold (0.54 log units) below, outside the stated range (above it).
By their numbers in this assay, from the lowest: compound 2; then compounds 1 and 3 (each within the scatter of the next).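

In this assay the exchange of 1,3-benzoxazol-2-yl for 1,3-benzothiazol-2-yl, on an aromatic carbon ortho to a fluoro group, now has a direct reading, and it amounts to a 1.8-fold higher number from compound 1 to compound 3 (0.26 log units; within the scatter). Going by these compounds alone, that pair is the only direct reading of any single change, and it places compound 1 and compound 3 within the usual scatter of each other, so the two groups cannot be told apart at this position on this read-out, and the single exchange of ring oxygen for ring sulfur gives no resolved shift here. No supporting measurement accompanies the pair, so the data offer no explanation for the reading.

As far as these compounds go, it remains open whether this exchange would read the same on a core carrying other substituents, since it has been seen on the core of compound 1 alone. Also open, from the compounds shown here alone, is how far the number would move if this position carried a different group altogether, such as a morpholine, a carboxylic acid or a pyridine ring.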